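Dichlorophenyl rearrangement on a dimethoxybenzylidene cyclohexanone core

The source may hold more compounds than are shown below. What is called first, only, known or untested is meant among the compounds shown, and "the series" means these compounds.

Compound 1 `COc1cccc(/C=C2\CCC/C(=C\c3ccc(Cl)c(Cl)c3)C2=O)c1OC` gives 9000 nM in a functional assay on MCF7 cells (Homo sapiens) for cytotoxicity, read by MTT assay, with a stated time of 72 h; a higher number here means a weaker inhibitor, a lower number a stronger inhibitor. Compound 2 `COc1cccc(/C=C2\CCC/C(=C\c3cc(Cl)cc(Cl)c3)C2=O)c1OC` differs from it by 3,5-dichlorophenyl in place of 3,4-dichlorophenyl on a double-bonded chain carbon bound to a double-bonded ring carbon and gives 4300 nM; the step of a 2.1-fold lower number from compound 1 to compound 2 (0.32 log units; beyond the scatter) shows that this change lowered the number beyond the scatter. Compound 3 `COc1ccc(/C=C2\CCC/C(=C\c3ccc(Cl)c(Cl)c3)C2=O)cc1OC` carries a different core; how the two cores differ is not broken down here. Compound 3 gives 4400 nM in this assay, a number close to that of compound 2. Compound 4 `COc1ccc(/C=C2\CCC/C(=C\c3cc(Cl)cc(Cl)c3)C2=O)cc1OC` has not been measured. Among the compounds with values here, it differs from compound 3 by 3,5-dichlorophenyl in place of 3,4-dichlorophenyl on a double-bonded chain carbon bound to a double-bonded ring carbon, the same change as the one from compound 1 to compound 2. Because that earlier step was a 2.1-fold lower number from compound 1 to compound 2 (0.32 log units; beyond the scatter), a step of similar size is expected for compound 4, a 2.0-fold lower number from compound 3 to compound 4 (0.30 log units; within the scatter). Compound 4 is therefore estimated to give 2200 nM in this assay, within a range from 1000 nM to 4800 nM.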

Compound 4, half-maximal inhibitory concentration: 3800 nM
For compound 4 the middle estimate is 1.7-fold (0.24 log units) below the measured one; measured number inside the range.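

In this assay, 3,5-dichlorophenyl in place of 3,4-dichlorophenyl gives a 1.2-fold lower number from compound 3 to compound 4 (0.06 log units; within the scatter). The two steps for this change, on the two cores, cannot be told apart: the same change on two cores in this assay, a 2.1-fold lower number (0.32 log units; beyond the scatter) from compound 1 to compound 2 and a 1.2-fold lower number (0.06 log units; within the scatter) from compound 3 to compound 4, 1.8-fold (0.26 log units) apart, within the scatter of two such steps. The result is thus compatible with the change carrying from one core to the other, but it does not show a shared effect, as only two cores are shown and only the first step lies beyond the scatter.

The compounds shown leave open whether the step holds on a core with hydroxyl groups in place of the methoxy groups. They also leave open how the number moves with fluorine or bromine in place of chlorine, or with a pyridine ring in place of the dichlorophenyl.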